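A few compounds are considered here, and "the series" means these few. Any claim that something is new, unique, unknown or untested is made for them only; others in the source may bear on it.

Working notes on the series. Two compounds have numbers in an in vivo ADME assay on the whole organism (strain Sprague-Dawley) for pharmacokinetics, with Rattus norvegicus as the target, at a dose of 2 mg/kg by the oral route; a higher number here means that a larger share of the oral dose reaches the circulation, a lower number that a smaller share of the oral dose reaches the circulation. Compound 1 `Cc1c(F)cc(C(=O)NC2CC2)cc1-c1cc2cnnc(-c3ccc(F)cc3F)c2n(C)c1=O` gives 55% in this assay. Compound 2 `Cc1cnc(C(=O)NC2CC2)cc1-c1cc2cnnc(-c3ccccc3C)c2n(C)c1=O` gives 132% in this assay, the highest of the two numbers; the gap down to compound 1 lies beyond the usual scatter. For the measured compounds named here, compound 1 and compound 2 differ from each other in more than one place, so no single step between measured compounds can be read from this pair. Compound 3 `Cc1cnc(C(=O)NC2CC2)cc1-c1cc2cnnc(-c3ccc(F)cc3C)c2n(C)c1=O` differs from compound 2 in exactly one place: fluoro in place of hydrogen on an aromatic carbon. Going by the values given here, no measured pair isolates this change, so the size of the step rests on expectation alone; in this assay a small step, in either direction or none beyond the scatter, is expected from compound 2 to compound 3. Compound 3 is estimated at 105% in this assay, with a range from 60% to 145%, corresponding to the expected step of a number 27 percentage points lower from compound 2 to compound 3 (beyond the scatter).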

Compound 3, oral bioavailability: 116%
For compound 3 the middle estimate is 11 percentage points below the measured one; the range from low to high includes it.
By their numbers in this assay, from the lowest: compound 1; then compound 3; then compound 2.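

The change from 2-methylphenyl to 4-fluoro-2-methylphenyl now has a measured size: in this assay, fluoro in place of hydrogen on the aromatic carbon para to a large group gives a number 16 percentage points lower from compound 2 to compound 3 (beyond the scatter), a modest step beyond the scatter. The position therefore accepts fluoro at a modest cost in oral bioavailability, with compound 3 still at 116%. Nothing measured in the series accounts for the size or direction of this step.

On these data alone, it remains open how chloro, methoxy or an amine at this position would compare with fluoro. Steps to compound 1 cannot be read, as it differs from the other compounds in more than one place, so it is also open whether this fluoro step would hold with the other parts of the molecule changed.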